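Cytotoxicity flat from compound 1 toward compound 3

The source may report more compounds than this note shows. Statements on the series, on what has been measured and on what is new or still open speak of the compounds shown alone.

Measured compounds:
compound 1 `CCc1cccc(NC(=O)C2CCCN(C(=O)c3cc(C(F)(F)F)cc(C(F)(F)F)c3)C2)c1` — in an ADME assay on PC-3 cells (Homo sapiens) for cytotoxicity, read by WST assay, tested at 100 uM (on this read-out higher numbers stand for more inhibition at the one concentration tested (going by the name of the read-out) and lower numbers for less inhibition), compound 1 gives 0%
compound 2 `O=C(Nc1cccc(S(=O)(=O)N2CCCC2)c1)C1CCCN(C(=O)c2cc(C(F)(F)F)cc(C(F)(F)F)c2)C1` — compound 2 gives 0%
compound 3 `O=C(Nc1ccc(Cl)cn1)C1CCCN(C(=O)c2cc(C(F)(F)F)cc(C(F)(F)F)c2)C1` — not yet measured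

Compound 1 stands level with compound 2 at the digits shown; neither shows any inhibition in this assay at the single concentration tested. Going by the values given here, the only measured step, no change at the digits printed from compound 1 to compound 2 (within the scatter), replaced ethyl with (pyrrolidin-1-yl)sulfonyl on an aromatic carbon and left the read-out unchanged within the scatter. Compound 3 differs from compound 1 as follows: 5-chloropyridin-2-yl in place of 3-ethylphenyl on an amide-type nitrogen. This change sits on the amide-type nitrogen and exchanges the whole 3-ethylphenyl ring for 5-chloropyridin-2-yl, so the measured step, which altered a substituent on the ring rather than the ring itself, bears on it only loosely. Still, that step was flat, and both measured compounds sit at the floor of the read-out, so no step beyond the scatter is expected in this assay, that is no change at the digits printed from compound 1 to compound 3 (within the scatter). Compound 3 is therefore estimated at 0%, with a range from -10% to 15%.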

Compound 3, a percentage reported as inhibition, at one concentration (the size of the read-out at that concentration, not a potency): 0%
Compound 3: middle estimate and measured number agree at the digits printed; the range from low to high includes it.
By their numbers in this assay, from the lowest: compounds 1, 2 and 3 (each within the scatter of the next).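

In this assay, the earlier step altered only a substituent on the ring, whereas no change at the digits printed from compound 1 to compound 3 (within the scatter) exchanges the whole 3-ethylphenyl ring on the amide-type nitrogen for 5-chloropyridin-2-yl, bringing in a ring nitrogen, a chlorine and a hydrogen-bond acceptor. The amide-type nitrogen therefore carries either a carbon-only aromatic ring or a six-membered aromatic ring with a hetero atom with no step beyond the scatter, although a read-out sitting at its floor cannot separate compounds that all lie there. Nothing on hand offers a measured reason for this flat result.

The compounds shown leave open whether a different group on this nitrogen, such as a phenyl ring bearing a carboxylic acid or a primary amine, or a straight butyl chain in place of the ring, would move the read-out beyond the scatter. They also leave open whether the result would hold at any concentration other than the single one used, and whether a change elsewhere in the shared core, away from the amide-type nitrogen, would alter it.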